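The source may report more compounds than this note shows. Statements on the series, on what has been measured and on what is new or still open speak of the compounds shown alone.

The measured compounds in a functional assay on Ehrlich cells (Mus musculus) for cytotoxicity, tested at 50 ug/mL (a higher number here means a stronger effect of the compound at the concentration tested, a lower number a weaker effect), are these:
compound 1 `COc1ccc(C2C(C#N)=C(N)N(c3cc(OC)c(OC)c(OC)c3)C3=C2C(=O)CC(C)(C)C3)cc1` gives 11%;
compound 2 `COc1cc(N2C(N)=C(C#N)C(/C=C/c3ccccc3)C3=C2CC(C)(C)CC3=O)cc(OC)c1OC` gives 30%;
compound 3 `COc1cc(N2C(N)=C(C#N)C(c3ccc(Cl)cc3Cl)C3=C2CC(C)(C)CC3=O)cc(OC)c1OC` gives 95%.

Compound 3 stands highest of the three numbers, its steps to both other compounds lying beyond the scatter: a number 84 percentage points higher from compound 1 to compound 3 (beyond the scatter) and a number 65 percentage points higher from compound 2 to compound 3 (beyond the scatter). The smaller step of a number 19 percentage points higher from compound 1 to compound 2 (beyond the scatter) also concerns the same saturated ring carbon, so every measured change in this set sits at that one position.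

Compound 4 `COc1cc(N2C(N)=C(C#N)C(c3ccccc3)C3=C2CC(C)(C)CC3=O)cc(OC)c1OC` is the next member. Its difference from compound 3 is phenyl in place of 2,4-dichlorophenyl on a saturated ring carbon. The two steps into compound 3 both bear on this change, since each of them put 2,4-dichlorophenyl in place of another group at that carbon and each gave a large rise. Among the measured compounds shown here, compound 4 reverses that, taking the 2,4-dichlorophenyl away and leaving plain phenyl, which no measured compound carries. A drop is therefore expected, likely large, though its exact size cannot be read from the three compounds. The expected step is a number 55 percentage points lower from compound 3 to compound 4 (beyond the scatter). For compound 4 in this assay the estimated value is 40%, with a range from 15% to 75%.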

Compound 4, a percentage reported as activity, at one concentration (the size of the read-out at that concentration, not a potency): 8%
Compound 4: the middle estimate sits 32 percentage points above what was measured; the measured number lies below the stated range.
By their numbers in this assay, from the lowest: compounds 4 and 1 (each within the scatter of the next); then compound 2; then compound 3.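

In this assay, the high reading at this saturated ring carbon proves to depend on the chlorine atoms of the 2,4-dichlorophenyl group rather than on the presence of an aromatic ring there, since taking away only those two chlorines gives a number 87 percentage points lower from compound 3 to compound 4 (beyond the scatter). Substitution on that ring does not always count, however: the change of methoxy to hydrogen on an aromatic carbon gives a number 3 percentage points lower from compound 1 to compound 4 (within the scatter), so plain phenyl and 4-methoxyphenyl cannot be told apart here, while 2,4-dichlorophenyl stands well clear of both. The 2-phenylethenyl group also keeps a smaller margin over plain phenyl, seen in a number 22 percentage points lower from compound 2 to compound 4 (beyond the scatter), so a group without chlorine can still raise the reading at this carbon, though far less than 2,4-dichlorophenyl does.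

The compounds shown leave open whether one chlorine on the phenyl ring would be enough, and whether bromine, fluorine or a nitro group would serve in place of the chlorines. Nothing given explains the effect of the chlorines on the reading.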